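Benzylsulfanyl for propylamino on the purine-side analogue

The source may hold more compounds than are shown below. What is called first, only, known or untested is meant among the compounds shown, and "the series" means these compounds.

Measured so far in an ADME assay on MOLT-3 cells (Homo sapiens) for cytotoxicity, with a stated time of 7 days; on this read-out lower numbers stand for higher toxicity in this test and higher numbers for lower toxicity in this test:

- compound 1, `CC(C)CSc1nc(N)nc2c1ncn2/C=C1/CC1(CO)CO`: "not determined" (no result reported)
- compound 2, `Nc1nc2c(ncn2/C=C2/CC2(CO)CO)c(=O)[nH]1`: > 20000 nM
- compound 3, `CCCNc1nc(N)nc2c1ncn2/C=C1/CC1(CO)CO`: "not determined" (no result reported)

Compound 3 stands without a number of its own in this assay; for it the entry is empty. Compound 1 likewise has no result reported. For the measured compounds named here, compound 2 is the only member with an entry, and that entry is a limit of the assay, not a number: compound 2 gives > 20000 nM. Among the three entries, one sits at the limit of > 20000 nM in this assay, at which 1 of the 3 values shown sits, and the other two are blank, so the series as measured gives no step between any two compounds and no spread to compare against.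

The next compound is compound 4, `Nc1nc(SCc2ccccc2)c2ncn(/C=C3/CC3(CO)CO)c2n1`. It differs from compound 3 in one place: benzylsulfanyl in place of propylamino on an aromatic carbon.

Going by the values given here, since no measured step exists for this change, no size or direction can be read from the data; the only anchor is the limit seen for compound 2 in this assay. The working expectation is that compound 4 shows no toxicity beyond what the scatter would hide and again runs up against the assay ceiling. The estimate for compound 4 in this assay is 50000 nM, with a range from 10000 nM to 200000 nM.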

Compound 4, half-maximal cytotoxic concentration: > 20000 nM
Compound 4 was reported as a limit (the forecaster's own chance of this, stated with the estimate: 60%); the middle value does not contradict the limit.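

No new step can be read between compound 3 and compound 4 in this assay. Compound 4 gives > 20000 nM, which is a limit of the assay and not a number: the limit of > 20000 nM in this assay, at which 2 of the 4 values shown sit.

The compounds shown leave open what benzylsulfanyl in place of propylamino does to the read-out, and at what concentration any member of the series becomes toxic in this assay.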